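The source may hold more compounds than are shown below. What is called first, only, known or untested is meant among the compounds shown, and "the series" means these compounds.

Measured in a functional assay on the whole organism (strain albino) for inhibition, with Rattus norvegicus as the target, read by paw edema, with a stated time of 4 h, at a dose of 0.28 mmol/kg by the oral route; on this read-out higher numbers stand for more inhibition at the one dose given (going by the name of the read-out) and lower numbers for less inhibition:
- compound 1, `COc1ccc(-c2nnc(SCC(=O)c3ccccc3)n2-c2ccccc2)cc1OC`, gives 65%
- compound 2, `COc1cc(-c2nnc(SC/C(=N/O)c3ccccc3)n2-c2ccccc2)cc(OC)c1OC`, gives 76%
- compound 3, `C=CCn1c(SCC(=O)c2ccccc2)nnc1-c1cc(OC)c(OC)c(OC)c1`, gives 66%

The three values sit close together. Compound 3 stands second of the three numbers; its nearest neighbour is compound 1, its furthest compound 2, and both gaps lie within the usual scatter of repeated measurements, so no ordering among the three can be read from these numbers. Among the compounds with values here, no pair among them differs in only one place, so no single step is available to calibrate the change that follows.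

Compound 4, `COc1cc(-c2nnc(SCC(=O)c3ccccc3)n2-c2ccccc2)cc(OC)c1OC`, is the next compound to be measured. Its difference from compound 3 is phenyl in place of allyl on an aromatic nitrogen. Compound 4 thus carries the same group on the ring nitrogen as compound 1 and the same substituted aryl group as compound 2 and compound 3; both of those compounds, and compound 1 as well, lie in the same narrow band in this assay. On that basis the step of a number 2 percentage points higher from compound 3 to compound 4 (within the scatter) is expected to be none beyond the scatter. Compound 4 is therefore estimated at 68%, with a range from 57% to 80%.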

Compound 4, a percentage reported as inhibition, in the whole organism at one dose (the size of the read-out at that dose, not a potency): 73%
Estimate against measurement, compound 4: 5 percentage points below; measured number inside the range.
By their numbers in this assay, from the lowest: compounds 1, 3, 4 and 2 (each within the scatter of the next, the first and the last beyond it).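

In this assay, phenyl in place of allyl on an aromatic nitrogen gives a number 7 percentage points higher from compound 3 to compound 4 (within the scatter), so at this ring nitrogen an aromatic ring and a short unsaturated chain cannot be told apart by this read-out. The other two single changes also stay inside the scatter: methoxy in place of hydrogen on an aromatic carbon gives a number 8 percentage points higher from compound 1 to compound 4 (within the scatter), and the group of 8 heavy atoms in place of the group of 9 heavy atoms, on a saturated chain carbon bound to a sulfur, gives a number 3 percentage points lower from compound 2 to compound 4 (within the scatter), so none of the three places yet shows a step that can be told from repeat variation. No further measurement bears on why these steps come out as they do.

From the compounds shown here alone, whether methyl, benzyl or a longer chain ending in an amine on the same ring nitrogen would move the read-out beyond the scatter remains open. So does the effect of a carboxylic acid or an amide in place of the benzoyl part on the sulfur, and with one dose and one read-out the compounds give no potency.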